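Swapping the aryl ketone: from fluorine to two methyl groups

The source may report more compounds than this note shows. Statements on the series, on what has been measured and on what is new or still open speak of the compounds shown alone.

Of the compounds shown here, three share one core and have been tested in a functional assay on the whole organism (Ear) for inhibition, with Mus musculus as the target, with a stated time of 30 min, at a dose of 100 mg/kg by the intraperitoneal route; on this read-out lower numbers stand for less inhibition and higher numbers for more inhibition at the one dose given (going by the name of the read-out). Compound 1, `O=C(/C=C/c1ccc(/C=N/NC(=O)c2ccncc2)cc1)c1cccc(Br)c1`, gives 14%. Compound 2, `Cc1ccc(C(=O)/C=C/c2ccc(/C=N/NC(=O)c3ccccc3)cc2)c(C)c1`, gives 0.18%. Compound 3, `O=C(/C=C/c1ccc(/C=N/NC(=O)c2ccncc2)cc1)c1ccc(F)cc1`, gives 51.1%, the highest of the three numbers, with compound 1 beyond the scatter below it and compound 2 further below still. Going by the values given here, the one single-point step measured so far, a number 37.1 percentage points higher from compound 1 to compound 3 (beyond the scatter), came from putting 4-fluorophenyl in place of 3-bromophenyl on the carbonyl carbon, so the aryl group on that carbonyl has already moved the read-out by a large amount.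

Compound 4, `Cc1ccc(C(=O)/C=C/c2ccc(/C=N/NC(=O)c3ccncc3)cc2)c(C)c1`, is to be measured next. It differs from compound 3 in one place: 2,4-dimethylphenyl in place of 4-fluorophenyl on a carbonyl carbon. Among the compounds with values here, compound 2 carries the same 2,4-dimethylphenyl, but with a different hydrazide part, so no direct step links it to compound 4; its value only shows that this aryl group has so far sat with a low number. The change is therefore expected to lower this assay by a number 31.1 percentage points lower from compound 3 to compound 4 (beyond the scatter), with compound 4 estimated at 20%, within a range from 2% to 48%.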

Compound 4, a percentage reported as inhibition, in the whole organism at one dose (the size of the read-out at that dose, not a potency): 58.5%
Compound 4: middle estimate off by 38.5 percentage points, on the low side; the whole stated range lies below it.
By their numbers in this assay, from the lowest: compound 2; then compound 1; then compounds 3 and 4 (each within the scatter of the next).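

In this assay, 2,4-dimethylphenyl and 4-fluorophenyl on this carbonyl carbon cannot be told apart (a number 7.4 percentage points higher from compound 3 to compound 4 (within the scatter)), so this change has no readable effect, and the aryl group alone does not bring the low number that compound 2 suggested. Set against 3-bromophenyl, 2,4-dimethylphenyl gives a large step (a number 44.5 percentage points higher from compound 1 to compound 4 (beyond the scatter)), so 3-bromophenyl now stands apart from both other aryl groups with the pyridin-4-yl kept in place. The largest step comes with 2,4-dimethylphenyl held fixed, from pyridin-4-yl in place of phenyl on a carbonyl carbon (a number 58.3 percentage points higher from compound 2 to compound 4 (beyond the scatter)), which shows that this second site can matter at least as much as the aryl ketone.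

Nothing available explains why any of these steps has its size. Still open, from the compounds shown here alone, is whether pyridin-4-yl has the same effect with other aryl groups, and whether an amine or a carboxylic acid on the aryl ring would keep the read-out.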